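A few compounds are considered here, and "the series" means these few. Any claim that something is new, unique, unknown or untested is made for them only; others in the source may bear on it.

Measured compounds in the series:

- compound 1, `CCN(CC)CC(=O)N1N=C(C)CC1c1ccccc1O`: 39800 nM
- compound 2, `O=C(c1ccccc1)N1N=C(c2cc3ccccc3oc2=O)CC1c1ccccc1`: 12700 nM

Both values come from a functional assay on MGC-803 cells (Homo sapiens) for cytotoxicity, read by MTT assay, with a stated time of 48 h; a higher number here means a weaker inhibitor, a lower number a stronger inhibitor. Of the two numbers, compound 2 gives the lower one; the gap to compound 1 is beyond the scatter, so compound 2 is the stronger inhibitor of the pair in this assay. For the measured compounds named here, no single-site step between the two measured compounds can be drawn, since they differ at more than one place, and nothing in the data ties the acyl group alone to the gap.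

Compound 3, `CC1CCCN(CC(=O)N2N=C(c3cc4ccccc4oc3=O)CC2c2ccccc2)C1`, is not yet measured. It keeps the core of compound 2 and differs from it in one place: (3-methylpiperidin-1-yl)methyl in place of phenyl on a carbonyl carbon. Going by the values given here, no measured step reports this change, so the expectation rests only on the two values shown. Compound 1 carries a related aminoalkyl acyl group and gives the weaker number, but it also differs elsewhere, so that cannot be read as a step. The expected step from compound 2 to compound 3 is a 1.4-fold higher number from compound 2 to compound 3 (0.15 log units; within the scatter), a moderate weakening that may not clear the scatter. Compound 3 is therefore estimated at 18000 nM in this assay, with a range from 6000 nM to 50000 nM.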

Compound 3, half-maximal inhibitory concentration: "not active" (no number reported)
No number was reported for compound 3, and the estimate cannot be compared.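

For the compounds shown here, compound 3 is reported as "not active" with no number, so no step from compound 2 to compound 3 can be read. The compounds shown leave open how far the change from benzoyl to ((3-methylpiperidin-1-yl)methyl)carbonyl moves the value on the shared core. No supporting data bear on this result.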